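The compounds below may be only part of what the source reports. "The series", "measured", "known", "first", "only" and "open" are said of these compounds alone.

Compound 2 `COCCCCCCCCCCC/C=C1\CC(CO)(COC(=O)C(C)(C)C)OC1=O` sits at the ceiling of what a functional assay on NCI-H322 cells (Homo sapiens) for antiproliferative activity (a lower number here means a stronger inhibitor of growth, a higher number a weaker inhibitor of growth), can report: in this assay compound 2 gives > 10 ug/mL, which is a limit of the assay rather than a number. Compound 1 `CC(C)(C)C(=O)OCC1(CO)C/C(=C\CCCCCCCCCCCO)C(=O)O1` shows the same kind of limit, giving > 10 ug/mL in this assay. Among the measured compounds shown here, the one measured step, a step that the two limits leave unreadable from compound 1 to compound 2, therefore has no readable size. Compound 3 `CC(=O)OCCCCCCCCCCCCCCC/C=C1\CC(CO)(COC(=O)C(C)(C)C)OC1=O` differs from compound 2 by 4-acetoxybutyl in place of methoxy on a saturated chain carbon, ten or more bonds along the chain from a double-bonded chain carbon. For the measured compounds named here, with both known values sitting at the limit of > 10 ug/mL in this assay, at which 2 of the 2 values shown sit, no measured step offers guidance, and no shift beyond the scatter is expected. Compound 3 is thus estimated at 15 ug/mL, between 7 ug/mL and 40 ug/mL. This amounts to an expected step that the limit leaves unreadable from compound 2 to compound 3.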

Compound 3, concentration for 50% growth inhibition: > 10 ug/mL
Compound 3 gave a limit, no number; the forecaster's own chance of this, stated with the estimate: 80%; the middle value lies beyond the limit too.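

No step among compound 1, compound 2 and compound 3 can be read, because each value is a limit of the assay and not a number: the limit of > 10 ug/mL in this assay, at which 3 of the 3 values shown sit.

As far as these compounds go, how strongly each compound inhibits growth, and whether the group changed on the chain matters at all, stays open.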